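Ester chain lengthening on the shared core: cytotoxicity notes

The source may report more compounds than this note shows. Statements on the series, on what has been measured and on what is new or still open speak of the compounds shown alone.

The series rests on the core of compound 1 `COc1ccc(Cc2coc3cccc(O)c3c2=O)cc1`. In a functional assay on H9c2 cells (Mus musculus) for cytotoxicity against H9c2 (Rattus norvegicus), read by MTT assay, with a stated time of 24 h (a lower number here means that less compound is needed, a higher number that more compound is needed for the effect), compound 1 reaches only the limit of the assay, > 100000 nM. Compound 2 `COc1ccc(Cc2coc3cc(OC(C)=O)cc(O)c3c2=O)cc1` carries an acetoxy in place of hydrogen on an aromatic carbon. In this assay compound 2 likewise reaches only the limit, > 100000 nM. The step that the two limits leave unreadable from compound 1 to compound 2 is therefore of unreadable size, and its direction cannot be told either. Compound 2 thus stands at the limit of > 100000 nM in this assay, at which 2 of the 2 values shown sit; nothing beyond that limit is known for it, and no number places it against compound 1.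

Compound 3 `CCC(=O)Oc1cc(O)c2c(=O)c(Cc3ccc(OC)cc3)coc2c1` differs from compound 2 by methyl in place of hydrogen on a saturated chain carbon bound to a carbonyl carbon. Within the data shown here, no measured step gives a readable size for a change of this kind, since the only step in hand sits between two limits. With both measured values at the limit, there is no number from which a direction could be read. Compound 3 is expected to remain at the limit, the step that the limit leaves unreadable from compound 2 to compound 3 being taken as none beyond the scatter. For compound 3 in this assay the estimate is 200000 nM, between 70000 nM and 600000 nM, most likely reported again only as a limit.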

Compound 3, half-maximal effective concentration: > 100000 nM
Compound 3: a limit, no number; the forecaster's own chance of this, stated with the estimate: 85%; the middle value does not contradict the limit.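

In this assay compound 3 gives > 100000 nM, which is a limit and not a number. No step among compound 1, compound 2 and compound 3 can be read, in size or in direction: the limit of > 100000 nM in this assay, at which 3 of the 3 values shown sit.

The compounds shown leave open whether acetoxy or propanoyloxy on the shared core changes the cytotoxicity at all.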